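This account rests on a few compounds, and the source may have more. Where it says the series, first, only, none or still open, it means among the compounds named here.

In a functional assay on HL-60 cells (Homo sapiens) for cytotoxicity, read by XTT assay, with a stated time of 72 h (a lower number here means a stronger inhibitor, a higher number a weaker inhibitor), compound 3 (`CCn1ccc2cc(/C(=N\OC(C)=O)c3cc(OC)c(OC)c(OC)c3)ccc21`) gives > 1000 nM, which is a limit and not a number. Compound 1 (`CCn1ccc2cc(/C(=N\O)c3cc(OC)c(OC)c(OC)c3)ccc21`) gives > 1000 nM, also a limit. Compound 2 (`COc1cc(/C(=N\OC(C)=O)c2ccc3c(ccn3C)c2)cc(OC)c1OC`) gives > 10000 nM, again a limit. Compound 4 (`CCn1ccc2cc(/C(=N/OC(C)=O)c3cc(OC)c(OC)c(OC)c3)ccc21`) differs from compound 3 in one respect: the two compounds have the same atoms and bonds and differ only in configuration as drawn: 1 of 1 stereo elements differ; a double bond is drawn E in compound 3 and Z in compound 4. Going by the values given here, the only measured step, a step that the two limits leave unreadable from compound 1 to compound 3, puts acetyl in place of hydrogen on an oxygen, so it gives no size for a change of configuration. With no measured number to scale from, any readable result for compound 4 would most likely fall on the stronger side of the limit held by compound 3. The estimated step, an at least 3.3-fold lower number from compound 3 to compound 4 (0.52 log units; beyond the scatter), is therefore expected toward stronger inhibition, with wide uncertainty. Compound 4 is expected at about 300 nM, with an estimated range of 30 nM to 3000 nM.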

Compound 4, half-maximal inhibitory concentration: > 1000 nM
Compound 4: only a limit was reported; the forecaster's own chance of this, stated with the estimate: 45%; middle value at least 3.3-fold (0.52 log units) away from the limit.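

In this assay compound 4 gives > 1000 nM, which is a limit. Its steps from compound 3 and compound 2 therefore cannot be read. The compounds shown leave open whether the configuration of the double bond changes cytotoxicity at all.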